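A few compounds are considered here, and "the series" means these few. Any claim that something is new, unique, unknown or untested is made for them only; others in the source may bear on it.

Within the data shown here, compound 1 `Fc1ccc(C2CC(c3ccc(Cl)s3)=NN2c2nc(-c3ccc(C(F)(F)F)cc3)cs2)cc1` is one of the two measured members. In an ADME assay on NIH3T3 cells (Mus musculus) for cytotoxicity, read by XTT assay, with a stated time of 24 h (a higher number here means a weaker inhibitor, a lower number a stronger inhibitor), compound 1 gives > 500 ug/mL, which is a limit of the assay and not a number. Compound 2 `Cc1ccc(C2=NN(c3nc(-c4ccc(C(F)(F)F)cc4)cs3)C(c3ccc(F)cc3)C2)s1` differs from compound 1 by methyl in place of chloro on an aromatic carbon. In this assay compound 2 gives > 500 ug/mL, again a limit rather than a number. The step that the two limits leave unreadable from compound 1 to compound 2 is therefore not readable in size, and what the measured pair shows is only (the limit of > 500 ug/mL in this assay, at which 2 of the 2 values shown sit). Compound 3 `O=[N+]([O-])c1ccc(-c2csc(N3N=C(c4ccc(Cl)s4)CC3c3ccc(F)cc3)n2)cc1` differs from compound 1 by nitro in place of trifluoromethyl on an aromatic carbon. Among the measured compounds shown here, no measured step covers nitro in place of trifluoromethyl, so nothing among the measured compounds points to a change beyond the scatter in either direction. The expectation is that compound 3 also sits at the limit, with the step that the limit leaves unreadable from compound 1 to compound 3 expected to be small. The estimate for compound 3 in this assay is 600 ug/mL, in the range 250 ug/mL to 1500 ug/mL.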

Compound 3, half-maximal inhibitory concentration: > 500 ug/mL
Compound 3 gave a limit, no number; the forecaster's own chance of this, stated with the estimate: 70%; the middle value does not contradict the limit.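

The step from compound 1 to compound 3 cannot be read, as both results are limits and not numbers: the limit of > 500 ug/mL in this assay, at which 3 of the 3 values shown sit.

The compounds shown leave open whether compound 1, compound 2 and compound 3 differ at all in this assay, and which change to the shared core would give a readable value.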